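The compounds below may be only part of what the source reports. "The series", "measured", "known", "first", "only" and "open" are said of these compounds alone.

Compound 1, `COc1ccc(C(C)NC(=O)/N=C(\N)NCCCc2sc(N)nc2C)cc1`: 0.91
Compound 2, `Cc1nc(N)sc1CCCN/C(N)=N/C(=O)NC(C)c1ccc(Br)cc1`: 0.87
Compound 3, `Cc1nc(N)sc1CCCN/C(N)=N/C(=O)NC(C)c1ccccc1F`: 0.93

Of the compounds shown here, three sharing one core have been measured in a functional assay on Right cardiac atrium for agonist activity at histamine H2 receptor (Cavia porcellus), with a stated time of 30 min, in the presence of a further agent that is not named here; a higher number here means a larger maximal response, a lower number a smaller maximal response. Compound 3 gives the largest of the three numbers, but the gaps are small: the step a number 0.020 higher from compound 1 to compound 3 (within the scatter) and the step a number 0.060 higher from compound 2 to compound 3 (within the scatter) both sit within the usual scatter of this assay, so the three compounds cannot be told apart on these numbers.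

The next compound, compound 4, `Cc1nc(N)sc1CCCN/C(N)=N/C(=O)NC(C)c1ccc(Cl)cc1`, has not yet been measured in this assay. It differs from compound 3 in one place: 4-chlorophenyl in place of 2-fluorophenyl on a saturated chain carbon bound to an amide-type nitrogen and a saturated chain carbon. Among the measured compounds shown here, three measured steps bear on this change. The step a number 0.040 lower from compound 1 to compound 2 (within the scatter) exchanges one group for another on an aromatic carbon of the same ring; the step a number 0.060 higher from compound 2 to compound 3 (within the scatter) exchanges the whole 4-bromophenyl for the 2-fluorophenyl; and the step a number 0.020 higher from compound 1 to compound 3 (within the scatter) exchanges the 4-methoxyphenyl for the 2-fluorophenyl. Every one of these lies within the scatter. Because of the step a number 0.060 higher from compound 2 to compound 3 (within the scatter), which runs in the opposite direction to the present change and still stays within the scatter, no step beyond the scatter is expected in this assay. Compound 4 is therefore estimated to give 0.89 in this assay, with a likely range from 0.8 to 0.97. The expected step is a number 0.040 lower from compound 3 to compound 4 (within the scatter).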

Compound 4, intrinsic activity: the largest response reached, as a fraction of the reference agonist's: 0.93
Beside the measured number, compound 4's estimate is 0.040 below it; low and high end bracket the measured number.
By their numbers in this assay, from the lowest: compounds 2, 1, 3 and 4 (each within the scatter of the next).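

In this assay, putting 4-chlorophenyl in place of 2-fluorophenyl on the saturated chain carbon gives no change at the digits printed from compound 3 to compound 4 (within the scatter), so this read-out does not separate a fluorine on the ring in the 2-position from a chlorine in the 4-position. The chloro group also cannot be told apart from the two other groups on the same aromatic carbon: with chloro in place of bromo the step is a number 0.060 higher from compound 2 to compound 4 (within the scatter), and with chloro in place of methoxy it is a number 0.020 higher from compound 1 to compound 4 (within the scatter). Four different substituted phenyl groups at this position therefore give maximal responses that cannot be told apart, and the addition of a chlorine-bearing ring leaves the earlier picture unchanged. The information given here offers no explanation for these results.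

Still open is whether an amine or a carboxylic acid on the aromatic ring, or a longer chain in place of the methyl on the saturated chain carbon, would also stay within the scatter of these compounds in this assay. Also open, going by these compounds, is whether these four compounds, so alike in their largest response, differ in the concentration needed to reach it.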